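The compounds below may be only part of what the source reports. "The series", "measured", "known", "first", "only" and "open" are said of these compounds alone.

Measured so far:
compound 1 `O=C(/C=C/c1ccc(OCc2cn(Cc3cccc(Br)c3)nn2)cc1)c1ccc(Br)cc1`: 44%
compound 2 `O=C(/C=C/c1ccc(OCc2cn(Cc3ccc(F)cc3)nn2)cc1)c1ccc(Br)cc1`: 43%

Among the compounds with values here, in a functional assay on A549 cells (Homo sapiens) for inhibition, read by MTT assay, with a stated time of 48 h, tested at 10 uM (on this read-out higher numbers stand for more inhibition of growth at the one concentration tested and lower numbers for less inhibition of growth), compound 1 is one of only two measured compounds, and a number 1 percentage points lower from compound 1 to compound 2 (within the scatter), so the two cannot be told apart. Compound 3 `COc1ccc(C(=O)/C=C/c2ccc(OCc3cn(Cc4cccc(Br)c4)nn3)cc2)cc1` differs from compound 1 by methoxy in place of bromo on an aromatic carbon, read one bond further out as (4-bromophenyl)carbonyl to (4-methoxyphenyl)carbonyl. Within the data shown here, the single measured step concerns the other end of the shared core and does not bear on this exchange, so nothing here supports expecting a change beyond the scatter in this assay. The estimate for compound 3 is 42%, between 22% and 62%. The expected step is a number 2 percentage points lower from compound 1 to compound 3 (within the scatter).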

Compound 3, percent growth inhibition at one concentration: 47%
Compound 3: the middle estimate sits 5 percentage points below what was measured; the range from low to high includes it.
By their numbers in this assay, from the lowest: compounds 2, 1 and 3 (each within the scatter of the next).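

In this assay, within the data shown here, methoxy in place of bromo on an aromatic carbon gives a number 3 percentage points higher from compound 1 to compound 3 (within the scatter), and compounds 1 and 2 both carried bromo here, so this is the only reading of a change at this position. Going from 4-bromophenyl to 4-methoxyphenyl adds a heavy atom and a hydrogen-bond acceptor, yet the two compounds cannot be told apart. No evidence at hand accounts for this result.

As far as these compounds go, whether an amine or a carboxylic acid at this position would move the number beyond the scatter remains open.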